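The source may report more compounds than this note shows. Statements on the series, on what has been measured and on what is new or still open speak of the compounds shown alone.

Working notes on the series. In a functional assay on isolated protein for agonist activity at Glucose-dependent insulinotropic receptor (Homo sapiens), read by HTRF and cAMP accumulation (on this read-out higher numbers stand for larger maximal responses and lower numbers for smaller maximal responses), compound 2 `C[C@@H](CF)OC(=O)N1CCC(O[C@H]2CC[C@H](Oc3cnc(S(C)(=O)=O)cn3)CC2)CC1` gives 105% and compound 1 `CC(C)(C)OC(=O)N1CCC(O[C@H]2CC[C@H](Oc3ccc(S(C)(=O)=O)nn3)CC2)CC1` gives 97%. Compound 2 stands at a number that compound 1 matches within the usual scatter, so the two are not separated on this read-out. Compound 3 `CC(C)c1noc(CN2CCC(O[C@H]3CC[C@H](Oc4cnc(S(C)(=O)=O)cn4)CC3)CC2)n1` has not yet been measured. It differs from compound 2 by a group of 9 heavy atoms (6 carbon, 2 nitrogen, 1 oxygen; one five-membered aromatic ring with 3 hetero atoms) in place of a group of 7 heavy atoms (4 carbon, 2 oxygen, 1 fluorine; no ring), on an amine nitrogen in a ring. Among the measured compounds shown here, no step between measured compounds bears on such a change. Because compound 2 already gives 105%, the step is expected to stay within the scatter: a number 8 percentage points lower from compound 2 to compound 3 (within the scatter) is the estimated step. Compound 3 is expected to give 97%, in a range of 72% to 115%.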

Compound 3, largest response reached (Emax), in percent of the reference or control that the assay uses: 102%
Beside the measured number, compound 3's estimate is 5 percentage points below it; the measured number falls inside the stated range.
By their numbers in this assay, from the lowest: compounds 1, 3 and 2 (each within the scatter of the next).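

In this assay the (3-isopropyl-1,2,4-oxadiazol-5-yl)methyl group on the amine nitrogen in a ring, in place of the open-chain group carrying fluorine, gives a number 3 percentage points lower from compound 2 to compound 3 (within the scatter) and so no separation on this read-out. This position thus accepts a five-membered aromatic ring with 3 hetero atoms, and the defined stereocentre of the group that leaves is not needed for the maximal response. Nothing at hand accounts for this result. Open, on these data alone, is how a free amine or a simple methyl on this nitrogen would behave, and whether trifluoromethyl could stand in place of the isopropyl.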